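Debromination of compound 1 in the cytotoxicity series

The source may report more compounds than this note shows. Statements on the series, on what has been measured and on what is new or still open speak of the compounds shown alone.

In an ADME assay on MCF-10A cells (Homo sapiens) for cytotoxicity, read by sulforhodamine B assay, with a stated time of 48 h (on this read-out lower numbers stand for stronger inhibition of growth and higher numbers for weaker inhibition of growth), compound 1 `CN(C)CN1C(=O)C(=O)c2c(Br)cccc21` gives 67800 nM. This is the lowest of the three numbers recorded, yet compound 2 `Cc1ccc2nc(/N=C3\C(=O)N(CN(c4ccccc4)c4ccccc4)c4cccc(Cl)c43)sc2c1` gives 70000 nM and compound 3 `CCN(CC)CN1C(=O)C(=O)c2c(Br)cccc21` gives 113000 nM, both within the usual scatter of it, so no ranking of the three is supported. Within the data shown here, the one measured step, a 1.7-fold higher number from compound 1 to compound 3 (0.22 log units; within the scatter), concerns the saturated chain carbon bound to the amide-type nitrogen in a ring, not the aromatic ring, and stayed within the scatter. Compound 4 `CN(C)CN1C(=O)C(=O)c2ccccc21` differs from compound 1 by hydrogen in place of bromo on an aromatic carbon. Among the measured compounds shown here, no measured step bears on that place. For compound 4 a step of a 1.3-fold higher number from compound 1 to compound 4 (0.10 log units; within the scatter) is expected, not beyond the scatter. Compound 4 is therefore estimated at 85000 nM, with a range from 30000 nM to 250000 nM.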

Compound 4, concentration for 50% growth inhibition: 150000 nM
Beside the measured number, compound 4's estimate is 1.8-fold (0.25 log units) below it; the range from low to high includes it.
By their numbers in this assay, from the lowest: compounds 1, 2, 3 and 4 (each within the scatter of the next, the first and the last beyond it).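

In this assay hydrogen in place of bromo on the aromatic carbon gives a 2.2-fold higher number from compound 1 to compound 4 (0.34 log units; beyond the scatter) and is the only step shown beyond the scatter, though a modest one. The change from dimethylamino to diethylamino stayed within the scatter, so this aromatic carbon is the one place shown where a single change separates two compounds, with bromo giving the stronger inhibition of growth. Going by these compounds, whether fluoro, methoxy or a carboxylic acid at this carbon would fall nearer compound 1 or compound 4 stays open. No measurement here gives a reason for the step.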